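Lengthening the Acid Chain: From Compound 3 to Compound 4

The source may report more compounds than this note shows. Statements on the series, on what has been measured and on what is new or still open speak of the compounds shown alone.

Measured so far in an assay on HEK293 cells for inhibition of solute carrier family 22 member 12 (Homo sapiens), read by scintillation counting, with stated times of 30 min and 15 min; on this read-out higher numbers stand for weaker inhibition and lower numbers for stronger inhibition:
compound 1, `N#Cc1ccc(Oc2cnccc2SCCCCCC(=O)O)c2ccccc12`: compound 1 gives 4740 nM
compound 2, `N#Cc1ccc(Oc2cnccc2SCCCCCCC(=O)O)c2ccccc12`: compound 2 gives 3780 nM
compound 3, `N#Cc1ccc(Oc2cnccc2SCC(=O)O)c2ccccc12`: compound 3 gives 6970 nM

Compound 3 holds the highest of the three numbers, yet neither neighbour stands apart from it: the step was a 1.5-fold higher number from compound 1 to compound 3 (0.17 log units; within the scatter), and the wider one was a 1.8-fold higher number from compound 2 to compound 3 (0.27 log units; within the scatter). Among the two longer-chain compounds the step was a 1.3-fold lower number from compound 1 to compound 2 (0.10 log units; within the scatter), so the whole set sits inside the usual scatter.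

Compound 4, `N#Cc1ccc(Oc2cnccc2SCCCCC(=O)O)c2ccccc12`, differs from compound 3 by 3-carboxypropyl in place of carboxy on a saturated chain carbon bound to a sulfur. Going by the values given here, the steps that bear on this change are those from compound 3 to its longer-chain relatives and the step between those relatives, and all three stayed within the scatter. On that evidence the step from compound 3 to compound 4 is expected to be a 1.3-fold lower number from compound 3 to compound 4 (0.13 log units; within the scatter), with no direction that can be trusted. Compound 4 is therefore estimated at 5200 nM, with a range from 2500 nM to 10500 nM.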

Compound 4, half-maximal inhibitory concentration: 4220 nM
For compound 4 the middle estimate is 1.2-fold (0.09 log units) above the measured one; the range from low to high includes it.
By their numbers in this assay, from the lowest: compounds 2, 4, 1 and 3 (each within the scatter of the next).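

In this assay, 3-carboxypropyl in place of carboxy on a saturated chain carbon bound to a sulfur left compound 4 within the scatter of compound 3 (a 1.7-fold lower number from compound 3 to compound 4 (0.22 log units; within the scatter)). Compound 4 also stayed within the scatter of both longer-chain relatives (a 1.1-fold higher number from compound 2 to compound 4 (0.05 log units; within the scatter); a 1.1-fold lower number from compound 1 to compound 4 (0.05 log units; within the scatter)), so this added chain length fills the series without opening any readable difference, and these four compounds show no trend with chain length at this position. No measurement shown here offers an explanation for this flat result.

The compounds leave open whether the result would hold if the carboxylic acid gave way to an amide or a tetrazole, or if an oxygen took the place of the sulfur. They also leave open how a branched chain, or a chain carrying a ring, would read at this position.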